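The source may report more compounds than this note shows. Statements on the series, on what has been measured and on what is new or still open speak of the compounds shown alone.

Measured compounds:
compound 1, `Cc1ccc(-c2n[nH]cc2N2CCCNCC2)cc1`: 744 nM
compound 2, `Fc1cccc(-c2n[nH]cc2N2CCCNCC2)c1`: 656 nM

In an assay on isolated protein for binding affinity to 5-hydroxytryptamine receptor 3A (Homo sapiens) (on this read-out lower numbers stand for stronger inhibition and higher numbers for weaker inhibition), compound 1 gives 744 nM. In this assay compound 2 gives 656 nM; the two numbers lie within the scatter of each other, so compound 1 cannot be set apart from compound 2 on this read-out. Both share their core with the unmeasured compound 3, `Fc1ccc(-c2n[nH]cc2N2CCCNCC2)cc1`. Compound 3 differs from compound 1 by fluoro in place of methyl on an aromatic carbon. Among the measured compounds shown here, no pair of measured compounds differing in a single place exists here, so the size of this step has no direct precedent. The two measured compounds each carry a single small substituent on the same carbon ring and give numbers within the scatter of each other, which gives no ground to expect a step beyond the scatter in either direction. The expected step is small: a 1.1-fold lower number from compound 1 to compound 3 (0.03 log units; within the scatter). Compound 3 is accordingly estimated at 700 nM, with a range from 350 nM to 1400 nM.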

Compound 3, inhibition constant: 1810 nM
Beside the measured number, compound 3's estimate is 2.6-fold (0.41 log units) below it; the whole stated range lies below it.
By their numbers in this assay, from the lowest: compounds 2 and 1 (each within the scatter of the next); then compound 3.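

Fluoro in place of methyl on an aromatic carbon, para to a large group, gives a 2.4-fold higher number from compound 1 to compound 3 (0.39 log units; beyond the scatter) in this assay, so this position does respond to a single-atom exchange, and the response is modest in size. Fluoro on this carbon ring does not by itself go with the higher number: compound 2, which also carries fluoro, gives 656 nM. Nothing measured here accounts for the step.

Still open is whether the step reflects the loss of methyl or the arrival of fluoro, since no compound with plain hydrogen at this position is among those shown. From the compounds shown here alone, how larger or different groups here, such as chloro, methoxy or an amine, would place on this assay also remains unknown.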